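The source may report more compounds than this note shows. Statements on the series, on what has been measured and on what is new or still open speak of the compounds shown alone.

Within the data shown here, compound 1 `Nc1nc2cc(-c3nn(CCCCCC(=O)NO)c4ncnc(N)c34)ccc2o1` is the one compound here with a measured number: in a functional assay on HeLa cells (Homo sapiens) for inhibition, read by MTT assay, with a stated time of 72 h (a higher number here means a weaker inhibitor, a lower number a stronger inhibitor), compound 1 gives 15400 nM. A second compound, compound 2 `Nc1ncnc2c1c(-c1cnc3[nH]ccc3c1)nn2CC(=O)NO`, was tested in this assay but for compound 2 the entry reads "not determined" (no result reported), with no number reported, so compound 1 stands alone on the numbers shown, and there is no measured step between any two compounds to lean on.

Compound 3 `Nc1nc2cc(-c3nn(CCCCCCC(=O)NO)c4ncnc(N)c34)ccc2o1` is the next compound to be measured. It differs from compound 1 in one place: (hydroxycarbamoyl)methyl in place of hydroxycarbamoyl on a saturated chain carbon, five bonds along the chain from an aromatic nitrogen. Put simply, the saturated chain that carries the hydroxycarbamoyl end grows by one carbon, while the shared core and the chain's end group stay the same.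

Among the measured compounds shown here, because the only number available is the 15400 nM of compound 1, and no pair of measured compounds shows how a chain lengthened this way behaves, the expected step from compound 1 to compound 3 in this assay is small, at most within the usual scatter of repeated measurements, with no preferred direction: a 1.2-fold lower number from compound 1 to compound 3 (0.07 log units; within the scatter). Compound 3 is therefore estimated at 13000 nM, with a range from 4000 nM to 40000 nM.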

Compound 3, half-maximal inhibitory concentration: 6410 nM
Estimate against measurement, compound 3: 2.0-fold (0.31 log units) above, within the range that was stated.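

Among these compounds, the first measured step at this position shows that the chain length matters in this assay: with (hydroxycarbamoyl)methyl in place of hydroxycarbamoyl on a saturated chain carbon, five bonds along the chain from an aromatic nitrogen, the result is a 2.4-fold lower number from compound 1 to compound 3 (0.38 log units; beyond the scatter). A lower number means a stronger inhibitor here, so lengthening the saturated chain while keeping the shared core and the end group gives a modest gain in inhibition of these cells, one that goes beyond the usual scatter of repeated measurements. Nothing available gives a measured reason for this gain.

Among the compounds shown here, two chain lengths give only a single step, so they cannot show whether a still longer chain would continue the gain, level off or reverse it. They also leave open how much the hydroxycarbamoyl end itself contributes, a question that a carboxylic acid or an amine at the end of the same chain would address.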